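A few compounds are considered here, and "the series" means these few. Any claim that something is new, unique, unknown or untested is made for them only; others in the source may bear on it.

Measured compounds in this series:

Compound 1 `CC(C)N(Cc1cccc(OCCCCCC(=O)O)c1)C(=O)c1ccc(-c2ccoc2)cc1` — in an ADME assay on Raji cells (Homo sapiens) for cytotoxicity, read by CellTiter-Glo and resazurin assay, with a stated time of 72 h (on this read-out lower numbers stand for an effect already at smaller amounts and higher numbers for an effect only at larger amounts of compound), compound 1 gives > 26000 nM, which is a limit of the assay and not a number.
Compound 2 `CCOC(=O)CCCCCOc1cccc(CN(C(=O)c2ccc(-c3cccc(NC(C)=O)c3)cc2)C(C)C)c1` — in this assay compound 2 gives > 26000 nM, a limit.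
Compound 3 `CCOC(=O)CCCCCOc1cccc(CN(C(=O)c2ccc(-c3cccnc3)cc2)C(C)C)c1` — in this assay compound 3 gives > 26000 nM, a limit.

Compound 3 therefore stands at the limit of > 26000 nM in this assay, at which 3 of the 3 values shown sit, together with the two other measured compounds; no value in the series is a number. For the measured compounds named here, the only step between measured compounds, a step that the two limits leave unreadable from compound 2 to compound 3, cannot be read because both of its ends are limits.

Compound 4 `CCOC(=O)CCCCCOc1cccc(CN(C(=O)c2ccc(-c3ccc(C(C)=O)s3)cc2)C(C)C)c1` is not yet measured. It differs from compound 3 in one place: 5-acetylthiophen-2-yl in place of pyridin-3-yl on an aromatic carbon. Going by the values given here, no measured step gives a readable size for a change at this position; the one step that touches it is unreadable. No step beyond the scatter is expected from compound 3 to compound 4 in this assay, and the estimated step is a step that the limit leaves unreadable from compound 3 to compound 4. For compound 4 a value of 40000 nM is expected, within 15000 nM to 120000 nM, most likely reported again as a limit.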

Compound 4, half-maximal effective concentration: > 26000 nM
Compound 4: a limit, no number (the forecaster's own chance of this, stated with the estimate: 80%); the middle value lies beyond the limit too.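

No new step can be read for compound 4 against compound 2 or compound 3, because both ends of each step are limits: the limit of > 26000 nM in this assay, at which 4 of the 4 values shown sit.

The compounds shown leave open whether any change to the shared core would give a number rather than a limit in this assay.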